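The compounds below may be only part of what the source reports. "The series", "measured", "known", "first", "only" and "open" are said of these compounds alone.

Series notes. In an assay (Equus caballus) for inhibition of Thromboxane-A synthase (Homo sapiens), using microsomes (on this read-out higher numbers stand for weaker inhibition and lower numbers for stronger inhibition), compound 1 `CSC(CCC/C=C(\c1ccccc1)c1cccnc1)C(=O)O` gives 30 nM, compound 2 `CCOC(=O)CCCC/C=C(\c1ccccc1)c1cccnc1` gives 600 nM and compound 3 `CC(C)(CCCC/C=C(\c1ccccc1)c1cccnc1)C(=O)O` gives 45 nM. Compound 3 thus stands second highest of the three numbers, closest to compound 1 and furthest from compound 2. Compound 4 `O=C(O)CCC/C=C(\c1ccccc1)c1cccnc1` is the next step: carboxy in place of 2-carboxy-2-methylpropyl on a saturated chain carbon, three bonds along the chain from a double-bonded chain carbon. Of the measured steps, a 20-fold higher number from compound 1 to compound 2 (1.30 log units; beyond the scatter) and a 13-fold lower number from compound 2 to compound 3 (1.12 log units; beyond the scatter) were large, whereas a 1.5-fold higher number from compound 1 to compound 3 (0.18 log units; within the scatter) stayed within the scatter; the two acids lie close together, and compound 4 keeps the acid. The step of a 1.3-fold higher number from compound 3 to compound 4 (0.12 log units; within the scatter) is therefore expected to be small in this assay, with no clear direction. Compound 4 is estimated at 60 nM, within 20 nM to 200 nM.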

Compound 4, half-maximal inhibitory concentration: 30 nM
Estimate against measurement, compound 4: 2.0-fold (0.30 log units) above, within the range that was stated.
By their numbers in this assay, from the lowest: compounds 1, 4 and 3 (each within the scatter of the next); then compound 2.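

Carboxy itself, with no further chain carbons or substituents, serves as well at this place as the larger acid groups in this assay: a 1.5-fold lower number from compound 3 to compound 4 (0.18 log units; within the scatter) and no change at the digits printed from compound 1 to compound 4 (within the scatter) both stay within the scatter. The 2-carboxy-2-methylpropyl and carboxy(methylsulfanyl)methyl groups therefore add nothing readable over the shorter acid. The large step of a 20-fold lower number from compound 2 to compound 4 (1.30 log units; beyond the scatter) sets this shorter acid apart from the ethyl ester as well.

On these data alone, whether an amide in place of the carboxy group or a longer unbranched chain ending in a carboxylic acid would hold this level remains open. Nothing available here accounts for these steps.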